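A few compounds are considered here, and "the series" means these few. Any claim that something is new, unique, unknown or untested is made for them only; others in the source may bear on it.

Two of the three measured compounds have a plain number in a functional assay on the whole organism with Rattus norvegicus as the target; a lower number here means that less compound is needed, a higher number that more compound is needed for the effect. Compound 1, built as `CCCCCCc1ccc2nc(N)sc2c1`, gives 7 mg/kg in this assay. Compound 2, built as `Nc1nc2ccc(OCC(F)(F)C(F)(F)F)cc2s1`, gives 7.5 mg/kg in this assay. Compound 3, built as `COC(=O)Cn1c(=N)sc2cc(OC(F)(F)F)ccc21`, stands apart: in this assay it gives only > 10 mg/kg, which is a limit of the measurement and not a number. Compound 3 thus sits at the limit of > 10 mg/kg in this assay, at which 1 of the 3 values shown sits, so where it truly lies is not known.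

Compound 4, built as `CSCCn1c(=N)sc2cc(OC(F)(F)F)ccc21`, is not yet measured. Its difference from compound 3 is (methylsulfanyl)methyl in place of methoxycarbonyl on a saturated chain carbon bound to an aromatic nitrogen. Among the measured compounds shown here, no measured pair of compounds differs in one place, so nothing seen so far tells how such a swap moves the read-out.

The expectation for compound 4 is a small step from compound 3, toward somewhat less compound being needed in this assay, as an at least 1.2-fold lower number from compound 3 to compound 4 (0.09 log units; that floor lies within the scatter), though a result again at the limit would not surprise. The estimate for compound 4 in this assay is 8 mg/kg, within a range from 3 mg/kg to 25 mg/kg.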

Compound 4, dose for half-maximal effect: 1 mg/kg
Compound 4: the middle estimate sits 8.0-fold (0.90 log units) above what was measured; measured number below the stated range.
By their numbers in this assay, from the lowest: compound 4; then compounds 1 and 2 (each within the scatter of the next). At a limit, above all of these: compound 3.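

In this assay, putting (methylsulfanyl)methyl in place of methoxycarbonyl on a saturated chain carbon bound to an aromatic nitrogen gives an at least 10-fold lower number from compound 3 to compound 4 (1.00 log units; beyond the scatter), the only one-place comparison among the compounds shown. This shows that the group at this place can strongly change how much compound is needed, by more than the usual scatter. The true size of the step stays unknown because compound 3 has only a limit and not a number: the limit of > 10 mg/kg in this assay, at which 1 of the 4 values shown sits.

A single pair cannot separate the loss of the carbonyl from the arrival of the sulfur, since the change from (methoxycarbonyl)methyl to 2-(methylsulfanyl)ethyl brings both at once. From the compounds shown here alone, it remains open whether a 2-methoxyethyl group, a plain propyl chain or a chain ending in an amine would need as little compound as the 2-(methylsulfanyl)ethyl group does.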